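Three chalcone analogues and a pending fourth in Huh-7 cells

The source may report more compounds than this note shows. Statements on the series, on what has been measured and on what is new or still open speak of the compounds shown alone.

Three compounds sharing one core were tested in a functional assay on Huh-7 cells (Homo sapiens) for inhibition, read by sulforhodamine B assay, with a stated time of 72 h; on this read-out higher numbers stand for weaker inhibition and lower numbers for stronger inhibition. Compound 1 `COc1ccc(C(=O)/C=C/c2cn(-c3ccccc3)nc2-c2cccnc2)c(OC)c1OC` gives 2300 nM in this assay. Compound 2 `COc1ccc(C(=O)/C=C/c2cn(-c3ccccc3)nc2-c2cccnc2)c(OC)c1` differs from compound 1 by hydrogen in place of methoxy on an aromatic carbon. In this assay compound 2 gives 2400 nM; the step of a 1.0-fold higher number from compound 1 to compound 2 (0.02 log units; within the scatter) is small. Compound 3 `COc1ccc(C(=O)/C=C/c2cn(-c3ccccc3)nc2-c2ccncc2)c(OC)c1OC` differs from compound 1 by pyridin-4-yl in place of pyridin-3-yl on an aromatic carbon. In this assay compound 3 gives 3700 nM; the step of a 1.6-fold higher number from compound 1 to compound 3 (0.21 log units; within the scatter) is also small, so the three values sit close together.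

Compound 4 `COc1ccc(C(=O)/C=C/c2cn(-c3ccccc3)nc2-c2ccncc2)cc1OC` has not yet been measured. It differs from compound 3 by hydrogen in place of methoxy on an aromatic carbon. This is the same kind of change as that from compound 1 to compound 2, but not the same: in compound 1 the departing methoxy sits ortho to two methoxy groups and meta to a large group, whereas in compound 3 it sits ortho to a large group, ortho to a methoxy group and meta to a methoxy group. The cores of compound 3 and compound 4 match that of compound 1 apart from pyridin-4-yl in place of pyridin-3-yl on an aromatic carbon.

For the measured compounds named here, the only precedent for removing a methoxy is the step from compound 1 to compound 2, which stayed within the scatter. The step from compound 3 to compound 4 is therefore expected to be about a 1.1-fold higher number from compound 3 to compound 4 (0.03 log units; within the scatter), with the outcome in this assay estimated near 4000 nM, most likely between 2000 nM and 8000 nM, because the measured step of a 1.0-fold higher number from compound 1 to compound 2 (0.02 log units; within the scatter) was so small. The number for compound 4 is awaited.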

Compound 4, half-maximal inhibitory concentration: 2000 nM
For compound 4 the middle estimate is 2.0-fold (0.30 log units) above the measured one; the measured number falls inside the stated range.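

In this assay, hydrogen in place of methoxy on the core carrying pyridin-4-yl gives a 1.9-fold lower number from compound 3 to compound 4 (0.27 log units; within the scatter), and the same change on the core carrying pyridin-3-yl gives a 1.0-fold higher number from compound 1 to compound 2 (0.02 log units; within the scatter), so both steps stay within the scatter. Set side by side, the two steps do not differ by more than repeated measurement would allow: the same change on two cores in this assay, a 1.0-fold higher number (0.02 log units; within the scatter) from compound 1 to compound 2 and a 1.9-fold lower number (0.27 log units; within the scatter) from compound 3 to compound 4, 1.9-fold (0.29 log units) apart, within the scatter of two such steps. This shows that, across these two pairs, the change carries from one core to the other without a step that can be read, but it does not show that the methoxy is without any influence in this series, since two small steps in a narrow band of values could hide a modest effect, and the departing methoxy does not stand in the same place on the ring in the two pairs.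

The compounds shown leave open whether a group other than hydrogen in that place, such as a hydroxyl, a fluorine atom or an amine, would give a step beyond the scatter. They also leave open what happens when the remaining methoxy groups are exchanged, singly or together, on either core.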